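Amide heteroaryl swap carried across two cores

The source may hold more compounds than are shown below. What is called first, only, known or untested is meant among the compounds shown, and "the series" means these compounds.

Compound 1 `O=C(Cn1c(-c2ccccc2)cc(-c2ccccc2)c1-c1ccccc1)Nc1nc2ccccc2s1` carries 1,3-benzothiazol-2-yl on an amide-type nitrogen whose other neighbour is the carbonyl carbon. In an ADME assay on HEK-293T cells (Homo sapiens) for cytotoxicity, read by MTT assay, with a stated time of 72 h, tested at 50 uM (a lower number here means less inhibition, a higher number more inhibition at the concentration tested (going by the name of the read-out)), compound 1 gives 55%. Compound 2 `CCc1nnc(NC(=O)Cn2c(-c3ccccc3)cc(-c3ccccc3)c2-c2ccccc2)s1` differs from compound 1 by 5-ethyl-1,3,4-thiadiazol-2-yl in place of 1,3-benzothiazol-2-yl on an amide-type nitrogen. In this assay compound 2 gives 49.3%, which is a step of a number 5.7 percentage points lower from compound 1 to compound 2 (within the scatter). Compound 3 `O=C(Cn1c(-c2ccc3ccccc3c2)cc(-c2ccccc2)c1-c1ccco1)Nc1nc2ccccc2s1` is built on another core; the difference between the core of compound 1 and the core of compound 3 is not broken down here. In this assay compound 3 gives 38.3%, the lowest of the three numbers and beyond the scatter from both compound 2 and compound 1.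

Compound 4 `CCc1nnc(NC(=O)Cn2c(-c3ccc4ccccc4c3)cc(-c3ccccc3)c2-c2ccco2)s1` is not yet measured. It differs from compound 3 by 5-ethyl-1,3,4-thiadiazol-2-yl in place of 1,3-benzothiazol-2-yl on an amide-type nitrogen, the same change as from compound 1 to compound 2, made at the same place, on an amide-type nitrogen whose other neighbour is the carbonyl carbon. The change occurs twice among these four compounds. On the core of compound 1 it made a step within the scatter, and with a single measured pair there is nothing to say that the second core will answer differently. For compound 4 the expected step in this assay is a number 5.3 percentage points lower from compound 3 to compound 4 (within the scatter), beside the earlier a number 5.7 percentage points lower from compound 1 to compound 2 (within the scatter), and it rests on that one pair alone. Compound 4 is estimated at 33% in this assay. The range for compound 4 is expected to run from 18% to 48%, set wide because compound 3 gives 38.3% well apart from the other two and the transfer of the step rests on one example.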

Compound 4, a percentage reported as inhibition, at one concentration (the size of the read-out at that concentration, not a potency): 83.6%
Beside the measured number, compound 4's estimate is 50.6 percentage points below it; the measured number lies above the stated range.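

In this assay, 5-ethyl-1,3,4-thiadiazol-2-yl in place of 1,3-benzothiazol-2-yl on an amide-type nitrogen gives a large step on the core of compound 3, a number 45.3 percentage points higher from compound 3 to compound 4 (beyond the scatter), and the two pairs do not agree: the same change on two cores in this assay, a number 5.7 percentage points lower (within the scatter) from compound 1 to compound 2 and a number 45.3 percentage points higher (beyond the scatter) from compound 3 to compound 4, 51 percentage points apart, beyond the scatter of two such steps In this series, then, the step read on the core of compound 1 does not carry over to the core of compound 3, so the effect of this change has to be read on each core separately. Two pairs show only that the outcome of the change differs with the core; they do not show which part of the core goes with the large step, what lies behind it, or how a third core would answer.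

From the compounds shown here alone, it stays open whether the large step follows the thiadiazole ring itself or its ethyl group, which a 5-methyl-1,3,4-thiadiazol-2-yl or an unsubstituted 1,3,4-thiadiazol-2-yl on the same amide-type nitrogen of the core of compound 3 could help to separate. Also open is which part of the difference in core matters, since the compounds shown offer no core that carries only a portion of it.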